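Working notes on the acyl group of the series

This account rests on a few compounds, and the source may have more. Where it says the series, first, only, none or still open, it means among the compounds named here.

compound 1 `Cc1nc(S(C)(=O)=O)ccc1Oc1ncnc(OC2CCN(C(=O)OC3CCC3)CC2)c1F`: 13.6 nM
compound 2 `CCC1(OC(=O)N2CCC(Oc3ncnc(Oc4ccc(S(C)(=O)=O)nc4C)c3F)CC2)CC1`: 22 nM

For the measured compounds named here, in a functional assay on isolated protein for inhibition of Glucose-dependent insulinotropic receptor (Homo sapiens), read by HTRF and cAMP accumulation (on this read-out higher numbers stand for an effect only at larger amounts of compound and lower numbers for an effect already at smaller amounts), compound 2 gives the highest of the two numbers so far, yet only a 1.6-fold higher number from compound 1 to compound 2 (0.21 log units; within the scatter) separates it from compound 1, so the two stand together. Compound 3 `Cc1nc(S(C)(=O)=O)ccc1Oc1ncnc(OC2CCN(C(=O)C3(C)CC3)CC2)c1F` differs from compound 2 by a group of 4 heavy atoms (4 carbon; one three-membered non-aromatic ring of carbon only) in place of a group of 6 heavy atoms (5 carbon, 1 oxygen; one three-membered non-aromatic ring of carbon only), on a carbonyl carbon; the entering group carries no hydrogen-bond acceptor. Going by the values given here, no measured step touches the carbonyl carbon itself; the single step available, a 1.6-fold higher number from compound 1 to compound 2 (0.21 log units; within the scatter), concerns the group on the oxygen and stayed within the scatter. Among the compounds with values here, with no precedent for losing that oxygen, a modest upward step is expected, a 1.4-fold higher number from compound 2 to compound 3 (0.13 log units; within the scatter), with wide uncertainty. Compound 3 is estimated at 30 nM, within 10 nM to 90 nM.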

Compound 3, half-maximal effective concentration: 761 nM
Beside the measured number, compound 3's estimate is 25-fold (1.40 log units) below it; the measured number lies above the stated range.
By their numbers in this assay, from the lowest: compounds 1 and 2 (each within the scatter of the next); then compound 3.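

In this assay, replacing the oxygen-linked group on the carbonyl carbon with 1-methylcyclopropyl gives a 35-fold higher number from compound 2 to compound 3 (1.54 log units; beyond the scatter) and a 56-fold higher number from compound 1 to compound 3 (1.75 log units; beyond the scatter) as two large steps beyond the scatter, whereas a 1.6-fold higher number from compound 1 to compound 2 (0.21 log units; within the scatter) stayed within it. This position therefore tolerates the change on the oxygen shown earlier but not this replacement. No supporting measurement bears on this loss.

Compound 3 loses the oxygen and changes the ring substituent at once, so the contribution of each remains unresolved. 1-Methylcyclopropyloxy on the carbonyl carbon would separate the two, while an amine there would test another linking atom.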